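A few compounds are considered here, and "the series" means these few. Any claim that something is new, unique, unknown or untested is made for them only; others in the source may bear on it.

Three compounds from this series have been examined in an ADME assay on LLC-MK2 cells (Macaca mulatta) for cytotoxicity, read by MTT assay, with a stated time of 48 h; a higher number here means that more compound is tolerated, a lower number that less compound is tolerated. Compound 1, `COc1ccc(/C=C(\C)C(=O)/C=C/c2ccccc2)cc1`, gives 44000 nM in this assay. Compound 2, `C/C(=C\c1ccc([N+](=O)[O-])cc1)C(=O)/C=C/c1ccccc1`, gives 264000 nM in this assay. The only difference between these two is nitro in place of methoxy on an aromatic carbon, and that change brought a 6.0-fold higher number from compound 1 to compound 2 (0.78 log units; beyond the scatter). Compound 3, `COc1ccc(/C=C/C(=O)/C(C)=C/c2ccc(N(C)C)cc2)cc1`, gives 285000 nM in this assay; its number is within the scatter of that of compound 2, while compound 1 sits beyond the scatter on the other side. The core of compound 3 differs from that of compound 1 in more than one place, and that difference is not broken down here.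

Compound 4, `C/C(=C\c1ccc(N(C)C)cc1)C(=O)/C=C/c1ccc([N+](=O)[O-])cc1`, has not yet been measured. It differs from compound 3 by nitro in place of methoxy on an aromatic carbon, which is the same change already seen between compound 1 and compound 2, at a place described in identical words. If that change repeats, compound 4 is expected to be tolerated at a higher concentration than compound 3, and the step from compound 3 is estimated at a 2.1-fold higher number from compound 3 to compound 4 (0.32 log units; beyond the scatter) in this assay. Among the measured compounds shown here, that expectation rests on the pair compound 1 and compound 2 with a 6.0-fold higher number from compound 1 to compound 2 (0.78 log units; beyond the scatter), though with only one precedent and compound 3 already near the high end of what has been observed, the step may be smaller. Compound 4 is therefore estimated at 600000 nM in this assay, with a range from 200000 nM to 1800000 nM.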

Compound 4, half-maximal cytotoxic concentration: 167000 nM
Compound 4: middle estimate off by 3.6-fold (0.56 log units), on the high side; the whole stated range lies above it.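

In this assay, nitro in place of methoxy on an aromatic carbon gave a 1.7-fold lower number from compound 3 to compound 4 (0.23 log units; within the scatter), so the clear step seen on the core of compound 1 did not reappear on the core of compound 3. Among the compounds shown here, the change therefore cannot be carried from one core to the other as a fixed step, and the comparison of the two results shows this directly: the same change on two cores in this assay, a 6.0-fold higher number (0.78 log units; beyond the scatter) from compound 1 to compound 2 and a 1.7-fold lower number (0.23 log units; within the scatter) from compound 3 to compound 4, 10-fold (1.01 log units) apart, beyond the scatter of two such steps What this does not show is which feature of the two cores separates the results, since they differ in more than one place and each core offers only a single pair, nor does it establish any rule for cores beyond these two.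

The compounds shown leave open whether a chlorine, an amine or a carboxylic acid on that aromatic carbon would follow the course seen on the core of compound 1 or the one seen on the core of compound 3. They also leave open what nitro in place of methoxy would do on a third core, including one that differs from these two in only a single place.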